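Shortening the chain and swapping the amine ring on compound 1

The compounds below may be only part of what the source reports. "The series", "measured", "known", "first", "only" and "open" are said of these compounds alone.

Measured compounds:
compound 1, `CN1CCN(CCCCCn2c3c(c4ccccc42)C(=O)c2c[n+]([O-])c4ccccc4c2C3=O)CC1`: 1710 nM
compound 2, `O=C1c2c[n+]([O-])c3ccccc3c2C(=O)c2c1c1ccccc1n2CCCCN1CCNCC1`: 460 nM
compound 3, `CCCCN1CCN(CCCCn2c3c(c4ccccc42)C(=O)c2c[n+]([O-])c4ccccc4c2C3=O)CC1`: 2150 nM

All three were tested in a functional assay on A-375 cells (Homo sapiens) for cytotoxicity, read by MTT assay, with a stated time of 72 h; on this read-out higher numbers stand for weaker inhibition and lower numbers for stronger inhibition. Compound 1 sits second highest of the three numbers. Its nearest neighbour is compound 3, with a 1.3-fold higher number from compound 1 to compound 3 (0.10 log units; within the scatter); the furthest is compound 2, with a 3.7-fold lower number from compound 1 to compound 2 (0.57 log units; beyond the scatter). Between the other two, a 4.7-fold higher number from compound 2 to compound 3 (0.67 log units; beyond the scatter).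

Compound 4, `O=C1c2c[n+]([O-])c3ccccc3c2C(=O)c2c1c1ccccc1n2CCCN1CCC(O)CC1`, is not yet measured. It differs from compound 1 in one place: 4-hydroxypiperidin-1-yl in place of 2-(4-methylpiperazin-1-yl)ethyl on a saturated chain carbon, three bonds along the chain from an aromatic nitrogen.

Among the compounds with values here, two measured steps bear on this change. The step from compound 1 to compound 2 also shortens the chain and ends in a ring bearing a hydrogen-bond donor, and it gave a modest fall in the number. The step from compound 1 to compound 3 kept the donor-free ring and stayed within the scatter. Within the data shown here, compound 4 likewise shortens the chain and brings in a ring with one hydrogen-bond donor, so a modest lowering of the number is expected, though the new ring is not the one seen in compound 2.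

For compound 4 the expected step is a 1.9-fold lower number from compound 1 to compound 4 (0.28 log units; within the scatter), giving an estimate of 900 nM with a range from 350 nM to 2500 nM.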

Compound 4, half-maximal inhibitory concentration: 240 nM
The estimate for compound 4 lay 3.8-fold (0.57 log units) above the measured number, and the stated range ends above it.
By their numbers in this assay, from the lowest: compounds 4 and 2 (each within the scatter of the next); then compounds 1 and 3 (each within the scatter of the next).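

In this assay, swapping 2-(4-methylpiperazin-1-yl)ethyl for 4-hydroxypiperidin-1-yl on a saturated chain carbon, three bonds along the chain from an aromatic nitrogen, gives a 7.1-fold lower number from compound 1 to compound 4 (0.85 log units; beyond the scatter) and the matching comparison with the butyl-bearing ring gives a 9.0-fold lower number from compound 3 to compound 4 (0.95 log units; beyond the scatter), which shows that a low number at the end of this chain does not depend on a piperazine ring. Within the data shown here, compound 4 also stands level with the one low-number compound known before it: a 1.9-fold lower number from compound 2 to compound 4 (0.28 log units; within the scatter) leaves the two indistinguishable in this assay, even though they differ in both chain length and ring, with a hydroxyl on one ring and a free ring amine hydrogen on the other. No measurement shown here explains why either end group gives a lower number than the substituted piperazines of compound 1 and compound 3.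

Each step to compound 4 alters the chain and the ring together, so the compounds shown cannot say how much of the difference belongs to each. Also open, going by these compounds, is how the 4-hydroxypiperidin-1-yl ring behaves on a longer chain, and whether a morpholin-4-yl ring or a 4-aminopiperidin-1-yl ring would do the same on this chain.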